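Fluorine on the benzyl arm of compound 1

A few compounds are considered here, and "the series" means these few. Any claim that something is new, unique, unknown or untested is made for them only; others in the source may bear on it.

compound 1 `Nc1nc(NCc2ccccc2)nc(-c2ccccc2CO)n1`: 4.35
compound 2 `Nc1nc(NCc2ccccc2)nc(-c2c(Cl)cccc2CO)n1`: 4.43
compound 3 `CC(C)Oc1ccc(-c2nc(N)nc(NCc3ccccc3)n2)c(CO)c1`: 4.91

In a functional assay on cells for positive allosteric modulation of G-protein coupled receptor 68 (Homo sapiens), read by a luciferase reporter and cAMP accumulation, with a stated time of 30 min, at pH 6.8 and pH 8.3, in the presence of a further agent that is not named here (a lower number here means a less potent compound, a higher number a more potent compound, by a factor of ten per unit of this negative logarithm), compound 1 gives the lowest of the three numbers, though compound 2 sits within the scatter of it, as a number 0.08 log units higher from compound 1 to compound 2 (within the scatter) shows, while a number 0.56 log units higher from compound 1 to compound 3 (beyond the scatter) is a modest step beyond the scatter. Compound 4 `Nc1nc(NCc2cccc(F)c2)nc(-c2ccccc2CO)n1` differs from compound 1 by fluoro in place of hydrogen on an aromatic carbon, which reads as benzyl to 3-fluorobenzyl. Neither measured step touches the benzyl arm: the chloro of compound 2 and the isopropoxy of compound 3 both enter on a different ring of the shared core. Among the compounds with values here, with no direct precedent, the expected change is a number 0.10 log units higher from compound 1 to compound 4 (within the scatter), not beyond the scatter. Compound 4 is therefore estimated at 4.45, with a range from 4 to 4.9.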

Compound 4, negative logarithm of the antagonist equilibrium constant: 4.52
Beside the measured number, compound 4's estimate is 0.07 log units below it, and the stated range covers the measured number.
By their numbers in this assay, from the lowest: compounds 1, 2 and 4 (each within the scatter of the next); then compound 3.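

Within the data shown here, this is the first measured change on the benzyl arm, since the earlier steps both lay on the other ring of the shared core. In this assay, the change from benzyl to 3-fluorobenzyl gives a number 0.17 log units higher from compound 1 to compound 4 (within the scatter), so at this place a single fluoro leaves the number within the scatter of the parent. Nothing measured here offers an explanation for this reading. Open, as far as these compounds go, is whether a methoxy, a trifluoromethyl or an amine at this place would shift the number beyond the scatter. Also open, from the compounds shown here alone, is whether the fluoro would hold its reading alongside the isopropoxy of compound 3.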